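The source may report more compounds than this note shows. Statements on the series, on what has been measured and on what is new or still open speak of the compounds shown alone.

In an ADME assay on the whole organism (Rattus norvegicus) for pharmacokinetics, at a dose of 1 mg/kg by the intravenous route (a higher number here means that more of the compound sits outside the plasma, a lower number that more of the compound stays in the plasma), compound 1 (`Cc1nnc(N2CCC(C(=O)N3N=CC[C@H]3c3ccccc3)CC2)o1`) gives 1.6 L/kg and compound 2 (`N#Cc1cnc(N2CCC(C(=O)N3N=CC[C@H]3c3cc(F)cc(F)c3)CC2)cn1`) gives 6.1 L/kg on the same scale. Compound 3 (`O=C(c1cn[nH]c1)N1CCC(C(=O)N2N=CCC2c2ccccc2)CC1`) gives 1.6 L/kg and so stands level with compound 1. These two share the lowest number of the three, with compound 2 higher by a margin beyond the scatter. Compound 4 (`O=C(c1c[nH]nn1)N1CCC(C(=O)N2N=CCC2c2ccccc2)CC1`) differs from compound 3 in one place: 1H-1,2,3-triazol-4-yl in place of 1H-pyrazol-4-yl on a carbonyl carbon. Both groups are five-membered aromatic rings with no net charge. For the measured compounds named here, no measured pair differing in one place is available to size such a change, so the expectation starts from compound 3 with its 1.6 L/kg as the reference. In this assay the expected change (a 1.1-fold lower number from compound 3 to compound 4 (0.06 log units; within the scatter)) is small, with no shift beyond the scatter in either direction. Compound 4 is estimated at 1.4 L/kg with an expected range from 0.8 L/kg to 2.6 L/kg once it is measured.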

Compound 4, volume of distribution at steady state: 1.3 L/kg
Estimate against measurement, compound 4: 1.1-fold (0.03 log units) above; low and high end bracket the measured number.
By their numbers in this assay, from the lowest: compounds 4, 1 and 3 (each within the scatter of the next); then compound 2.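

In this assay, for the compounds shown here, exchanging one five-membered aromatic ring for another on the carbonyl gives a 1.2-fold lower number from compound 3 to compound 4 (0.09 log units; within the scatter), the first step in this set that isolates a single place. At this position, then, a five-membered aromatic ring with 3 hetero atoms and one with 2 hetero atoms cannot be told apart in this read-out, as the step lies within the scatter. Nothing measured here accounts for this result.

The compounds shown leave open whether the number would hold with a group of another kind on that carbonyl carbon, such as a phenyl ring, a carboxylic acid or a dimethylamino group. They also leave open whether the same exchange would read alike with other groups on the shared core.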